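The source may hold more compounds than are shown below. What is called first, only, known or untested is meant among the compounds shown, and "the series" means these compounds.

Compounds measured in an assay for inhibition of squalene synthase (Rattus norvegicus), using microsomes; on this read-out higher numbers stand for weaker inhibition and lower numbers for stronger inhibition:

- compound 1, `C=CCc1cc(OC(=O)CC)ccc1OCCCNC(C)C`, 0.05 nM
- compound 2, `C=CCc1cc(-c2ccccc2)ccc1OCCCNC(C)C`, 0.004 nM
- compound 3, `C=CCc1cc(NC(C)=O)ccc1OCCCNC(C)C`, 65 nM

Compound 3 carries the highest number of the three in this assay. Its nearest neighbour is compound 1, reached by a 1300-fold higher number from compound 1 to compound 3 (3.11 log units; beyond the scatter), and the furthest is compound 2, reached by a 16000-fold higher number from compound 2 to compound 3 (4.21 log units; beyond the scatter). Both steps are large and both lie beyond the scatter, so compound 3 stands alone at the weak end.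

Compound 4, `C=CCc1cc(CO/N=C/C)ccc1OCCCNC(C)C`, differs from compound 3 in one place: a group of 5 heavy atoms (3 carbon, 1 nitrogen, 1 oxygen; no ring) in place of a group of 4 heavy atoms (2 carbon, 1 nitrogen, 1 oxygen; no ring), on an aromatic carbon. The entering group has no hydrogen-bond donor and two acceptors, whereas the acetamido that leaves has one donor and one acceptor.

Two measured steps bear on this change, the steps from compound 1 and from compound 2 to compound 3 given above. Each shows that the acetamido group goes with a far higher number than either the propanoyloxy group of compound 1 or the phenyl of compound 2. Within the data shown here, neither of those groups is the one entering in compound 4, so the expectation is indirect. Still, removing the acetamido group is the one move that has been tied to a large change, and the expected step from compound 3 to compound 4 is therefore a large fall in the number, estimated as a 130-fold lower number from compound 3 to compound 4 (2.11 log units; beyond the scatter). For compound 4 the estimated value in this assay is 0.5 nM, with a range from 0.03 nM to 10 nM.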

Compound 4, half-maximal inhibitory concentration: 0.2 nM
Compound 4: middle estimate off by 2.5-fold (0.40 log units), on the high side; the range from low to high includes it.
By their numbers in this assay, from the lowest: compound 2; then compound 1; then compound 4; then compound 3.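

At this position, on an aromatic carbon meta to the allyl group, this assay now shows a third group that stands far from acetamido, with a 330-fold lower number from compound 3 to compound 4 (2.51 log units; beyond the scatter); the high number of compound 3 therefore goes with acetamido itself, not with the absence of propanoyloxy or phenyl in particular. The new group, which has no ring, does not match phenyl, the one ring-bearing group shown, as a 50-fold higher number from compound 2 to compound 4 (1.70 log units; beyond the scatter) makes clear, so a clear order now separates the groups at the low end as well. Against propanoyloxy, another ringless group of equal heavy-atom count, the gap is much smaller but still beyond the scatter, with a 4.0-fold higher number from compound 1 to compound 4 (0.60 log units; beyond the scatter), so groups of the same size and with no ring are not interchangeable here.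

Going by these compounds, whether the low number of compound 2 needs a phenyl ring in particular, or would survive with a pyridyl or cyclohexyl ring, stays open, as does whether an N-methylacetamido group would keep the high number of compound 3. The data shown offer no measurement that explains any of these steps.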